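A few compounds are considered here, and "the series" means these few. Any claim that something is new, unique, unknown or untested is made for them only; others in the source may bear on it.

Compound 1, `Cc1nc(S(C)(=O)=O)ccc1Oc1ncnc(OC2CCN(C(=O)O[C@H](C)CF)CC2)c1F`, gives 1520 nM in a functional assay on isolated protein for inhibition of Glucose-dependent insulinotropic receptor (Rattus norvegicus), read by HTRF and cAMP accumulation; a lower number here means that less compound is needed, a higher number that more compound is needed for the effect. Compound 2, `Cc1nc(S(C)(=O)=O)ccc1Oc1ncnc(OC2CCN(C(=S)OC3(C)CC3)CC2)c1F`, gives 48.8 nM in this assay. Compound 3, `Cc1nc(S(C)(=O)=O)ccc1Oc1ncnc(OC2CCN(C(=O)C(C)(C)F)CC2)c1F`, gives 296 nM in this assay.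

Compound 1 has the highest of the three numbers. Its nearest neighbour is compound 3, reached by a 5.1-fold lower number from compound 1 to compound 3 (0.71 log units; beyond the scatter); the furthest is compound 2, reached by a 31-fold lower number from compound 1 to compound 2 (1.49 log units; beyond the scatter). All three compounds share the same core, and they differ only in the group attached to the amine nitrogen in the ring.

Compound 4, `CCC(F)(F)C(=O)N1CCC(Oc2ncnc(Oc3ccc(S(C)(=O)=O)nc3C)c2F)CC1`, differs from compound 1 in one place: a group of 5 heavy atoms (3 carbon, 2 fluorine; no ring) in place of a group of 5 heavy atoms (3 carbon, 1 oxygen, 1 fluorine; no ring), on a carbonyl carbon. Within the data shown here, the change most like it is the one from compound 1 to compound 3, where the group on the carbonyl carbon also lost its oxygen and kept a fluorine, and that step gave a 5.1-fold lower number from compound 1 to compound 3 (0.71 log units; beyond the scatter). The step from compound 1 to compound 2, a 31-fold lower number from compound 1 to compound 2 (1.49 log units; beyond the scatter), altered more of the group at once and is a weaker guide. A modest lower number is therefore expected for compound 4, close in size to the step to compound 3, which is a 4.8-fold lower number from compound 1 to compound 4 (0.68 log units; beyond the scatter). The estimate for compound 4 in this assay is 320 nM, with a range from 110 nM to 950 nM.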

Compound 4, half-maximal effective concentration: 69.2 nM
Compound 4: middle estimate off by 4.6-fold (0.67 log units), on the high side; the measured number lies below the stated range.
By their numbers in this assay, from the lowest: compounds 2 and 4 (each within the scatter of the next); then compound 3; then compound 1.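

In this assay, 1,1-difluoropropyl on the carbonyl carbon gives a 22-fold lower number from compound 1 to compound 4 (1.34 log units; beyond the scatter), a large step, so a group with no oxygen at this position can do far more than compound 3 first suggested. Compounds 3 and 4 both lack that oxygen, yet swapping 1-fluoro-1-methylethyl for 1,1-difluoropropyl still gives a 4.3-fold lower number from compound 3 to compound 4 (0.63 log units; beyond the scatter), so losing the oxygen does not account for the whole gain, and the make-up of the group on the carbonyl carbon matters in its own right. The step of a 1.4-fold higher number from compound 2 to compound 4 (0.15 log units; within the scatter) lies within the scatter, so compounds 2 and 4 cannot be told apart here, which shows that neither the sulfur nor the three-membered ring of compound 2 is needed to reach this level.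

No measurement shown offers a reason for any of these differences. Compounds 3 and 4 differ in both their fluorine count and the arrangement of their carbons, so the two effects remain unseparated; a plain propyl group or a 1,1-difluoroethyl group on the same carbonyl carbon would help to pull them apart.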